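The source may report more compounds than this note shows. Statements on the series, on what has been measured and on what is new or still open speak of the compounds shown alone.

Compounds measured in a functional assay on LOX IMVI cells (Homo sapiens) for inhibition; on this read-out lower numbers stand for stronger inhibition of growth and higher numbers for weaker inhibition of growth:

Compound 1, `COc1cc(/C=C/c2ccc(S(N)(=O)=O)cc2)cc(OC)c1`, gives 18200 nM.
Compound 2, `COc1cccc(/C=C/c2ccc(S(N)(=O)=O)cc2)c1`, gives 30700 nM.
Compound 3, `CN(C)c1ccc(/C=C/c2ccc(S(N)(=O)=O)cc2)cc1`, gives 18700 nM.

Compound 2 has the highest of the three numbers in this assay, yet its gaps to compound 3 and to compound 1 are both within the scatter, so no order among the three can be claimed. Among the compounds with values here, the only single-point step measured so far is a 1.7-fold higher number from compound 1 to compound 2 (0.23 log units; within the scatter), and that too stayed within the scatter.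

Compound 4, `NS(=O)(=O)c1ccc(/C=C/c2cccc(O)c2)cc1`, has not yet been measured. It differs from compound 2 in one place: hydrogen in place of methyl on an oxygen on an aromatic ring. Within the data shown here, no measured step touches this oxygen; the one step recorded concerns a methoxy leaving the ring entirely, and it moved the number by very little. Nothing in the three compounds suggests that this exchange should move the number beyond the scatter in either direction.

For compound 4 the number in this assay is therefore estimated at 25000 nM, with a range from 10000 nM to 60000 nM. This estimate means a step of a 1.2-fold lower number from compound 2 to compound 4 (0.09 log units; within the scatter), which is expected to fall within the scatter.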

Compound 4, concentration for 50% growth inhibition: 43000 nM
The estimate for compound 4 lay 1.7-fold (0.24 log units) below the measured number; the range from low to high includes it.
By their numbers in this assay, from the lowest: compounds 1, 3, 2 and 4 (each within the scatter of the next, the first and the last beyond it).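

In this assay, within the data shown here, the change from methoxy to hydroxy on the aromatic ring is the first measured exchange at this oxygen, and it gives a step that stays within the scatter (a 1.4-fold higher number from compound 2 to compound 4 (0.15 log units; within the scatter)). Among these compounds, the only earlier step removed a methoxy from the ring entirely (a 1.7-fold higher number from compound 1 to compound 2 (0.23 log units; within the scatter)), so the two compounds now add a second kind of change, with a hydrogen in place of the methyl while the oxygen stays on the ring, and neither step goes beyond the scatter. No independent information bears on this result, so the measured numbers stand without any explanation.

The compounds shown leave open whether a longer chain on this oxygen, such as ethyl or propyl, or an amine or a carboxylic acid in place of the hydroxy, would give a step beyond the scatter. Among the compounds shown here, with every single-place step so far inside the scatter, they also do not show whether any exchange at this place can clearly move the number in this assay in either direction.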